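Dihydroxyphenyl hydrazone on the shared benzothiazole-free core: a forecast

The source may hold more compounds than are shown below. What is called first, only, known or untested is meant among the compounds shown, and "the series" means these compounds.

Measured compounds:
compound 1 `O=C(N/N=C/c1cccnc1)c1ccc(-c2nc3ccccc3s2)cc1` — "not active" (no number reported)
compound 2 `O=C(N/N=C/c1ccc(O)cc1)c1ccc(-c2nc3ccccc3s2)cc1` — 11300 nM
compound 3 `COc1cc(/C=N/NC(=O)c2ccc(-c3nc4ccccc4s3)cc2)ccc1O` — 53300 nM

In an assay on isolated protein for inhibition of Maltase-glucoamylase (Homo sapiens), with a stated time of 15 min (on this read-out higher numbers stand for weaker inhibition and lower numbers for stronger inhibition), compound 1 is reported as "not active" (no number reported) with no number attached, so it stands at the weak end of the series without a value of its own. Compound 2 gives 11300 nM in this assay, and compound 3 gives 53300 nM. Going by the values given here, the only step between measured compounds is a 4.7-fold higher number from compound 2 to compound 3 (0.67 log units; beyond the scatter); it shows that adding a further substituent to the hydroxyphenyl ring moved the number upward.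

Compound 4 `O=C(N/N=C/c1cc(O)ccc1O)c1ccc(-c2nc3ccccc3s2)cc1` is not yet measured. It differs from compound 1 by 2,5-dihydroxyphenyl in place of pyridin-3-yl on a carbon with a double bond to nitrogen. The change in effect moves from the inactive compound 1 toward the hydroxylated aryl hydrazones represented by compound 2 and compound 3, with a second hydroxy group added. Among the compounds with values here, no measured step covers a second hydroxy directly; the one step that bears on it, a 4.7-fold higher number from compound 2 to compound 3 (0.67 log units; beyond the scatter), shows an extra group on that ring giving a modestly higher number. Compound 4 is therefore expected to land in the range of compound 2 and compound 3 rather than to be reported inactive like compound 1, with the wide uncertainty of a single indirect comparison. The estimate for compound 4 in this assay is 18000 nM, between 5000 nM and 70000 nM.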

Compound 4, half-maximal inhibitory concentration: 11900 nM
Beside the measured number, compound 4's estimate is 1.5-fold (0.18 log units) above it; low and high end bracket the measured number.
By their numbers in this assay, from the lowest: compounds 2 and 4 (each within the scatter of the next); then compound 3.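

In this assay, 2,5-dihydroxyphenyl on a carbon with a double bond to nitrogen gives a measurable value, whereas compound 1, with pyridin-3-yl at the same place, is reported as "not active" (no number reported), so the change between these two compounds cannot be read as a step of defined size. The second hydroxy group leaves the value within the scatter, with a 1.1-fold higher number from compound 2 to compound 4 (0.02 log units; within the scatter), while the comparison with the methoxy-bearing ring gives a 4.5-fold lower number from compound 3 to compound 4 (0.65 log units; beyond the scatter); the higher number seen for compound 3 therefore does not extend to every further group on the hydroxyphenyl ring, and compound 4 is the compound that goes against such a reading. Nothing available here bears on the reason for these differences.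

The compounds shown leave open whether any hydroxy group is needed for a measurable value, a question that an unsubstituted phenyl group at this place would address. They also leave open how an amine or a carboxylic acid on the ring would compare with the hydroxy groups of compound 2 and compound 4.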